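Half-life after furan-2-yl to thiophen-2-yl exchange

The source may report more compounds than this note shows. Statements on the series, on what has been measured and on what is new or still open speak of the compounds shown alone.

Measured so far in an ADME assay on cells (Hepatocyte, Mus musculus) for metabolic stability (on this read-out lower numbers stand for a shorter-lived compound and higher numbers for a longer-lived compound), for three compounds:
- compound 1 `O=C(NC1CCC(CN2CCN(c3cc(=O)c4cc(C(F)(F)F)cc([N+](=O)[O-])c4s3)CC2)CC1)c1ccccc1` gives > 1.55 h (a limit)
- compound 2 `O=C(OC1CCC(CN2CCN(c3cc(=O)c4cc(C(F)(F)F)cc([N+](=O)[O-])c4s3)CC2)CC1)c1ccco1` gives < 0.075 h (a limit)
- compound 3 `O=C(OC1CCC(CN2CCN(c3cc(=O)c4cc(C(F)(F)F)cc([N+](=O)[O-])c4s3)CC2)CC1)c1ccc(F)cc1` gives 0.0817 h (a number)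

Compound 2 has only a limit (the limit of < 0.075 h in this assay, at which 1 of the 3 values shown sits) and no number. Compound 4 `O=C(OC1CCC(CN2CCN(c3cc(=O)c4cc(C(F)(F)F)cc([N+](=O)[O-])c4s3)CC2)CC1)c1cccs1` differs from it by thiophen-2-yl in place of furan-2-yl on a carbonyl carbon in one place, with thiophen-2-yl in place of furan-2-yl on a carbonyl carbon. The closest measured change at this place is an at least 1.0-fold higher number from compound 2 to compound 3 (0.03 log units; that floor lies within the scatter) and its floor lies within the scatter. The changes an at least 20-fold lower number from compound 1 to compound 2 (1.31 log units; beyond the scatter) and an at least 18-fold lower number from compound 1 to compound 3 (1.27 log units; beyond the scatter) are large, but both replace benzamido on a saturated ring carbon, a change not made here. In this assay no step beyond the scatter is therefore expected. The expected step is a step that the limit leaves unreadable from compound 2 to compound 4 at this estimate. For compound 4 the estimated half-life is 0.07 h with an expected range from 0.03 h to 0.15 h overall.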

Compound 4, half-life: 0.0867 h
The estimate for compound 4 lay 1.2-fold (0.09 log units) below the measured number; the range from low to high includes it.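

In this assay, compound 4 gives a second number for an aromatic group on this carbonyl carbon, and exchanging 4-fluorophenyl for thiophen-2-yl gives a 1.1-fold higher number from compound 3 to compound 4 (0.03 log units; within the scatter). The comparison with the furan-2-yl compound, whose value is a limit, gives only an at least 1.1-fold higher number from compound 2 to compound 4 (0.06 log units; that floor lies within the scatter), so its size stays undetermined. The large gap to the benzamido compound also holds for this group, at an at least 17-fold lower number from compound 1 to compound 4 (1.25 log units; beyond the scatter).

On these data alone, how that gap divides between the ester oxygen and the aromatic group remains open. A (thiophen-2-yl)carbonylamino group in place of ((thiophen-2-yl)carbonyl)oxy would separate the two.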